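Triazole replacement at the benzylic-type carbon of compound 1

This account rests on a few compounds, and the source may have more. Where it says the series, first, only, none or still open, it means among the compounds named here.

Measured so far in an assay on CHO cells for displacement of a labelled ligand from prostaglandin E2 receptor EP3 subtype (Homo sapiens), read by radioligand binding; a lower number here means a stronger inhibitor, a higher number a weaker inhibitor:
compound 1, `CC(C)C(c1nnc[nH]1)c1ccc(-c2ccc3cccc(F)c3c2)[nH]c1=O`, 12 nM
compound 2, `CC(C)NC(=O)CC(c1ccc(-c2ccc3cccc(F)c3c2)[nH]c1=O)C(C)C`, 5.8 nM
compound 3, `CC(C)C(c1ccc(-c2ccc3cccc(F)c3c2)[nH]c1=O)N1CCN/C1=N\C#N`, 23 nM

Compound 1 gives the second highest number of the three, with compound 3 nearest to it and compound 2 furthest from it. Compound 4, `Cc1c[nH]c(C(c2ccc(-c3ccc4cccc(F)c4c3)[nH]c2=O)C(C)C)n1`, is not yet measured in this assay. Compared with compound 1 it carries 4-methyl-1H-imidazol-2-yl in place of 4H-1,2,4-triazol-3-yl on a saturated chain carbon bound to an aromatic carbon and a saturated chain carbon.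

Within the data shown here, two measured steps bear on this change, since both also swap out the 4H-1,2,4-triazol-3-yl group at the same saturated chain carbon. Going a 2.1-fold lower number from compound 1 to compound 2 (0.32 log units; beyond the scatter), an open-chain amide group in place of the triazole improved the number modestly. Going a 1.9-fold higher number from compound 1 to compound 3 (0.28 log units; within the scatter), a non-aromatic ring in place of the triazole stayed within the scatter. The three values thus span a narrow band, and neither step points to a large effect from what stands at this carbon. A 4-methyl-1H-imidazol-2-yl group keeps a five-membered aromatic ring with one hydrogen-bond donor, so compound 4 is expected to stay near compound 1, with no change at the digits printed from compound 1 to compound 4 (within the scatter) within the scatter. The estimate for compound 4 in this assay is 12 nM, with a range from 5 nM to 30 nM.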

Compound 4, inhibition constant: 12 nM
For compound 4 middle estimate and measured number coincide at the digits printed, and the stated range covers the measured number.
By their numbers in this assay, from the lowest: compound 2; then compounds 1, 4 and 3 (each within the scatter of the next).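

In this assay, the swap gives no change at the digits printed from compound 1 to compound 4 (within the scatter), so on this saturated chain carbon a five-membered aromatic ring with 2 hetero atoms and 1 hydrogen-bond acceptor cannot be told apart from one with 3 hetero atoms and 2 hydrogen-bond acceptors. The new group is also not separated from the non-aromatic five-membered ring group (a 1.9-fold lower number from compound 3 to compound 4 (0.28 log units; within the scatter)), whereas the (isopropylcarbamoyl)methyl group remains separated from it, though only modestly (a 2.1-fold higher number from compound 2 to compound 4 (0.32 log units; beyond the scatter)). No measurement bearing on these groups accompanies the series, so these steps cannot be tied to any cause.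

On these data alone, the share of the methyl within the 4-methyl-1H-imidazol-2-yl group stays open, as does the reading for a plain 1H-imidazol-2-yl group on the same carbon. Also open is whether this carbon stays as undemanding with a carboxylic acid, an amine or a longer chain ending in an amide, since every group shown here so far falls within a narrow band of values.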